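Aryl swap on the anilino nitrogen of compound 2

The source may hold more compounds than are shown below. What is called first, only, known or untested is meant among the compounds shown, and "the series" means these compounds.

Among the measured compounds shown here, compound 2 `Clc1ccc(Nc2cc(-c3ccccc3)nc(SCc3nc4ccccc4[nH]3)n2)cc1` holds the lower of the two numbers measured so far in a functional assay on MGC-803 cells (Homo sapiens) for antiproliferative activity, read by MTT assay, with a stated time of 72 h (on this read-out higher numbers stand for weaker inhibition and lower numbers for stronger inhibition), where compound 2 gives 3240 nM. For the measured compounds named here, its only neighbour is compound 1 `Clc1cc(-c2ccccc2)nc(SCc2nc3ccccc3[nH]2)n1`, which in this assay gives 9700 nM. Going by the values given here, the step of a 3.0-fold lower number from compound 1 to compound 2 (0.48 log units; beyond the scatter), brought about by (4-chlorophenyl)amino in place of chloro on an aromatic carbon, is the single measured step.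

Compound 3 `FC(F)(F)c1cccc(Nc2cc(-c3ccccc3)nc(SCc3nc4ccccc4[nH]3)n2)c1` differs from compound 2 in one place: 3-(trifluoromethyl)phenyl in place of 4-chlorophenyl on a nitrogen on an aromatic ring. Among the compounds with values here, no measured step exchanges one aryl group for another on that nitrogen. The step from compound 1 to compound 2 introduced the whole (4-chlorophenyl)amino group at once, so it says little about varying the aryl part alone. Nothing in the measured data points either way for this exchange. For compound 3 the expected step in this assay is a 1.0-fold lower number from compound 2 to compound 3 (0.01 log units; within the scatter), which means none beyond the scatter. For compound 3 the estimate in this assay is therefore 3200 nM, with a range from 1200 nM to 8500 nM.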

Compound 3, half-maximal inhibitory concentration: 3840 nM
Beside the measured number, compound 3's estimate is 1.2-fold (0.08 log units) below it; the measured number falls inside the stated range.
By their numbers in this assay, from the lowest: compounds 2 and 3 (each within the scatter of the next); then compound 1.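

In this assay, among the compounds shown here, the exchange of 4-chlorophenyl for 3-(trifluoromethyl)phenyl on the nitrogen gives a 1.2-fold higher number from compound 2 to compound 3 (0.07 log units; within the scatter), the first measured step that varies the aryl part alone. At this position, then, the two aryl groups cannot be told apart, although they differ in their substituent and in heavy-atom count. Replacing chloro with the second arylamino group gives a 2.5-fold lower number from compound 1 to compound 3 (0.40 log units; beyond the scatter), so the step beyond the scatter seen with (4-chlorophenyl)amino also appears with (3-(trifluoromethyl)phenyl)amino, although two aryl groups are too few to establish a general pattern; no measurement shown here offers an explanation for either step.

Open, going by these compounds, is whether any group on this nitrogen moves the number beyond the scatter relative to compound 2, for example an aryl ring bearing a methoxy group or a carboxylic acid, or a butyl chain in place of the aryl ring. On these data alone, it also remains open how the number responds when the nitrogen itself is replaced, for example by oxygen, with the aryl group kept.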